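This account rests on a few compounds, and the source may have more. Where it says the series, first, only, none or still open, it means among the compounds named here.

Measured so far:
compound 1, `CC1(C)Oc2ccc(C#N)cc2[C@@H](/N=C(\NC#N)Sc2ccccc2)[C@@H]1O`: 4900 nM
compound 2, `CCC(C)(C)/N=C(\NC#N)N[C@@H]1c2cc(C#N)ccc2OC(C)(C)[C@H]1O`: 29800 nM
compound 3, `CC1(C)Oc2ccc(C#N)cc2[C@@H](NC(=O)Nc2ccccn2)[C@@H]1O`: 440 nM

In a functional assay (aorta) with Rattus norvegicus as the target (a higher number here means a weaker inhibitor, a lower number a stronger inhibitor), compound 1 stands second highest of the three numbers. Its nearest neighbour is compound 2, which gives a number beyond the scatter above it, and the furthest is compound 3, which gives a number beyond the scatter below it. The three share the same core, and they differ only in the group attached to it.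

Compound 4, `Cc1ccc(N/C(=N/[C@@H]2c3cc(C#N)ccc3OC(C)(C)[C@H]2O)NC#N)cc1`, has not yet been measured. It differs from compound 1 in one place:

(4-methylphenyl)amino in place of phenylsulfanyl on a carbon with a double bond to nitrogen

For the measured compounds named here, no step between two measured compounds covers this change, so the expectation rests on the spread of the three numbers alone. Compound 3, the carrier of a hydrogen-bond donor in that position, gives the lowest number, and compound 2 the highest, so the change is expected to move compound 4 towards the lower number. The step is estimated to be a moderate drop, a 3.3-fold lower number from compound 1 to compound 4 (0.51 log units; beyond the scatter), beyond the scatter. Compound 4 is accordingly expected to give about 1500 nM, with a range from 300 nM to 8000 nM.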

Compound 4, half-maximal inhibitory concentration: 2700 nM
For compound 4 the middle estimate is 1.8-fold (0.26 log units) below the measured one; low and high end bracket the measured number.
By their numbers in this assay, from the lowest: compound 3; then compounds 4 and 1 (each within the scatter of the next); then compound 2.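

In this assay, for the compounds shown here, the exchange of phenylsulfanyl for (4-methylphenyl)amino on a carbon with a double bond to nitrogen gives a 1.8-fold lower number from compound 1 to compound 4 (0.26 log units; within the scatter), the first direct reading of a single change at this position. In this pair, therefore, swapping the sulfur link and its hydrogen-bond acceptor for a nitrogen link with a hydrogen-bond donor, together with the added methyl group, produces no difference that can be told from the usual scatter. Nothing measured on these groups is available to account for this result.

The compounds shown leave open how the linking atom and the methyl group each contribute, which a plain phenylamino group on the same carbon would help to separate. From the compounds shown here alone, it also remains open whether a chloro or methoxy group on the ring in place of the methyl would move the number beyond the scatter.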